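One group exchanged on compound 3

A few compounds are considered here, and "the series" means these few. Any claim that something is new, unique, unknown or untested is made for them only; others in the source may bear on it.

Within the data shown here, in a functional assay on K562 cells (Homo sapiens) for antiproliferative activity, read by MTT assay, with a stated time of 5 days (on this read-out higher numbers stand for weaker inhibition and lower numbers for stronger inhibition), compound 3 (`COc1ccc(C=C(C(=O)c2cc(OC)c(OC)c(OC)c2)c2ccccc2O)cc1O`) gives 35000 nM and holds the lowest of the three numbers so far. Compound 2 (`COc1ccc(C=C(C(=O)c2cc(OC)c(OC)c(OC)c2)c2ccccc2O)cc1`) reads 240000 nM and compound 1 (`COc1ccc(C(=Cc2ccc(OC)c([N+](=O)[O-])c2)C(=O)c2cc(OC)c(OC)c(OC)c2)cc1`) reads 2660000 nM on the same test. Compound 4 (`COc1ccc(C(=Cc2ccc(OC)c(O)c2)C(=O)c2cc(OC)c(OC)c(OC)c2)cc1`) has not yet been measured. It carries 4-methoxyphenyl in place of 2-hydroxyphenyl on a double-bonded chain carbon bound to a carbonyl carbon and a double-bonded chain carbon.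

Among the measured compounds shown here, the only measured step between close relatives is a 6.9-fold lower number from compound 2 to compound 3 (0.84 log units; beyond the scatter), a modest gain from hydroxy in place of hydrogen on an aromatic carbon. For the measured compounds named here, compound 4 keeps that hydroxy, so this step does not touch the exchanged group, and no measured step speaks to the swap directly. Compound 1 has 4-methoxyphenyl on that same carbon and its number lies far above that of compound 3, but it also differs from compound 4 in a further group. That gives a weak hint only.

The expected change in this assay is therefore a modest move toward weaker inhibition, with a 2.3-fold higher number from compound 3 to compound 4 (0.36 log units; beyond the scatter) as the estimated step. For compound 4 the estimate is 80000 nM, with an expected range from 10000 nM to 600000 nM around it.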

Compound 4, half-maximal inhibitory concentration: 12000 nM
The estimate for compound 4 lay 6.7-fold (0.82 log units) above the measured number, within the range that was stated.
By their numbers in this assay, from the lowest: compound 4; then compound 3; then compound 2; then compound 1.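

In this assay, putting 4-methoxyphenyl in place of 2-hydroxyphenyl on the double-bonded chain carbon gives a 2.9-fold lower number from compound 3 to compound 4 (0.46 log units; beyond the scatter), so at this place a group with 0 hydrogen-bond donors is compatible with a modestly stronger result, and the hydroxy of 2-hydroxyphenyl is not needed to reach this level of inhibition. The far larger change is hydroxy in place of nitro on an aromatic carbon, with a 220-fold lower number from compound 1 to compound 4 (2.35 log units; beyond the scatter) in this assay; both compounds carry 4-methoxyphenyl, so the very weak result of the nitro compound cannot be blamed on that group alone. No measurement shown here explains either change in terms of the properties of these groups.

Among these compounds, only one exchange at the double-bonded chain carbon can be read, so it remains open whether an unsubstituted phenyl, a 4-ethoxyphenyl or a phenyl bearing an amine would do as well as 4-methoxyphenyl. Equally open, from the compounds shown here alone, is how an amine or a carboxylic acid would compare with hydroxy and nitro on the aromatic carbon where those two were exchanged.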